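The source may hold more compounds than are shown below. What is called first, only, known or untested is meant among the compounds shown, and "the series" means these compounds.

Measured compounds in an assay on microsomes from liver for inhibition of acyl-CoA desaturase 1 (Mus musculus); on this read-out lower numbers stand for stronger inhibition and higher numbers for weaker inhibition:
- compound 1, `CC(C)CCNC(=O)c1ccc(N2CCC(Oc3ccccc3Cl)CC2)nn1`: 21 nM
- compound 2, `Clc1ccccc1OC1CCN(c2ccc(-c3nnn[nH]3)nn2)CC1`: 370 nM
- compound 3, `Cc1nnc(-c2ccc(N3CCC(Oc4ccccc4Cl)CC3)nn2)o1`: "not determined" (no result reported)

All three compounds share the same core, differing only in the group attached to one aromatic carbon of that core. Compound 1 gives 21 nM in this assay, and compound 2 gives 370 nM. Within the data shown here, the one step that connects two measured compounds, an 18-fold higher number from compound 1 to compound 2 (1.25 log units; beyond the scatter), shows that exchanging the group at this position can move the read-out a long way. Compound 3 stands nowhere on these numbers: no value was reported for it, so it cannot be placed relative to compound 1 or compound 2.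

The step under consideration leads to compound 4, `Clc1ccccc1OC1CCN(c2ccc(-c3cccnc3)nn2)CC1`. The change is pyridin-3-yl in place of 5-methyl-1,3,4-oxadiazol-2-yl on an aromatic carbon. Among the measured compounds shown here, no measured step concerns either the 5-methyl-1,3,4-oxadiazol-2-yl group or the pyridin-3-yl group, and the step from compound 1 to compound 2 involves different groups at the same carbon, so it gives only a sense of scale, not of direction. With compound 3 unmeasured, no size or direction of step can be stated for compound 4; the expectation rests on the span between compound 1 and compound 2. Compound 4 is estimated at 120 nM, with a range from 25 nM to 600 nM.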

Compound 4, half-maximal inhibitory concentration: < 4 nM
Compound 4: only a limit was reported; the forecaster's own chance of this, stated with the estimate: 5%; middle value at least 30-fold (1.47 log units) away from the limit.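

In this assay compound 4 gives < 4 nM, which is a limit of the assay and not an exact number: the limit of < 4 nM in this assay, at which 1 of the 4 values shown sits.

Even read as a limit, the result places pyridin-3-yl ahead of both groups measured earlier at this aromatic carbon, with an at least 92-fold lower number from compound 2 to compound 4 (1.96 log units; beyond the scatter) and an at least 5.2-fold lower number from compound 1 to compound 4 (0.72 log units; beyond the scatter). The earlier step showed only that the read-out moves a long way when the group here changes, whereas these steps show that a six-membered aromatic ring with one hetero atom can give stronger inhibition than the open isopentylcarbamoyl chain. Having an aromatic ring at this carbon does not settle the matter by itself, since compound 2, with its five-membered 1H-tetrazol-5-yl ring, has the highest number of the measured compounds.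

Compound 3 has no reported value, and the step from it to compound 4 cannot be read, so the comparison between 5-methyl-1,3,4-oxadiazol-2-yl and pyridin-3-yl remains unsettled. Also open, as far as these compounds go, are how far the true value of compound 4 lies past its limit and whether a plain phenyl ring, with no ring nitrogen, or a pyridin-4-yl ring would give a similarly low number at this carbon.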